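This account rests on a few compounds, and the source may have more. Where it says the series, first, only, none or still open, it means among the compounds named here.

Measured compounds and their numbers:

compound 1 `Cc1ccc(S(=O)(=O)/N=C(/CCNC2=CC(=O)c3ccccc3C2=O)Nc2ccc(F)cc2)cc1`: 4260 nM
compound 2 `Cc1ccc(S(=O)(=O)/N=C(/CCNC2=CC(=O)c3ccccc3C2=O)Nc2cccc(C(F)(F)F)c2)cc1`: 89100 nM
compound 3 `COc1ccc(N/C(CCNC2=CC(=O)c3ccccc3C2=O)=N\S(=O)(=O)c2ccc(C)cc2)c(OC)c1`: 30200 nM

All three share one core and differ only in the aryl group on an amine nitrogen. Tested in a functional assay on MCF7 cells (Homo sapiens) for cytotoxicity, read by MTT assay, with a stated time of 48 h (on this read-out lower numbers stand for stronger inhibition and higher numbers for weaker inhibition), compound 3 gives 30200 nM, the second highest of the three numbers. Its nearest neighbour is compound 2, separated by a 3.0-fold lower number from compound 2 to compound 3 (0.47 log units; beyond the scatter), while the other gap is wider: a 7.1-fold higher number from compound 1 to compound 3 (0.85 log units; beyond the scatter). The biggest swing in the set is a 21-fold higher number from compound 1 to compound 2 (1.32 log units; beyond the scatter).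

Compound 4 `Cc1ccc(S(=O)(=O)/N=C(/CCNC2=CC(=O)c3ccccc3C2=O)Nc2ccc(Cl)cc2Cl)cc1` is not yet measured. Its change from compound 3 is 2,4-dichlorophenyl in place of 2,4-dimethoxyphenyl on an amine nitrogen. Within the data shown here, no measured step exchanges two groups of this kind, so the expectation rests on indirect evidence: the one aryl group carrying a halogen atom, in compound 1, gave the lowest number, 4260 nM, and the 2,4-substitution pattern in compound 3 sat well above it. Compound 4 combines both features, so a modestly lower number than compound 3 is expected, but with wide uncertainty.

For compound 4 in this assay the estimate is 15000 nM, with a range from 3000 nM to 60000 nM. That expected step is a 2.0-fold lower number from compound 3 to compound 4 (0.30 log units; within the scatter).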

Compound 4, half-maximal inhibitory concentration: 17000 nM
For compound 4 the middle estimate is 1.1-fold (0.05 log units) below the measured one, and the stated range covers the measured number.
By their numbers in this assay, from the lowest: compound 1; then compounds 4 and 3 (each within the scatter of the next); then compound 2.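

In this assay the change of ring substituents gives a 1.8-fold lower number from compound 3 to compound 4 (0.25 log units; within the scatter) and so 2,4-dichlorophenyl and 2,4-dimethoxyphenyl cannot be told apart on this amine nitrogen. Halogen on the aryl group does not by itself set the number: there is a 4.0-fold higher number from compound 1 to compound 4 (0.60 log units; beyond the scatter) and also a 5.2-fold lower number from compound 2 to compound 4 (0.72 log units; beyond the scatter) so the halogen-bearing groups of compound 1, compound 2 and compound 4 span the lowest to the highest numbers of the set. No accompanying measurement offers an explanation for these differences.

The compounds shown leave open whether the low number of compound 1 belongs to fluorine itself or to a single substituent at that ring position, a question that a 4-chlorophenyl or 4-methoxyphenyl group would address. As far as these compounds go, an unsubstituted phenyl group is also absent from this set, so it remains unknown whether any of these substituents lowers or raises the number relative to the bare ring.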